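A few compounds are considered here, and "the series" means these few. Any claim that something is new, unique, unknown or untested is made for them only; others in the source may bear on it.

Measured so far:
- Compound 1, `O=C(O)CNc1ccc2ccc(C(=O)c3ccc(F)c(O)c3)nc2c1`: 3%
- Compound 2, `O=C(c1ccc(F)c(O)c1)c1ccc2ccccc2c1`: 64%
- Compound 3, `C=C(c1ccc(F)c(O)c1)c1cccc(-c2cccc(O)c2F)n1`: 88%

All three were tested in an assay for inhibition of 17-beta-hydroxysteroid dehydrogenase type 1 (Homo sapiens), read by HPLC, with a stated time of 10 min, tested at 1 uM; a lower number here means less inhibition, a higher number more inhibition at the concentration tested (going by the name of the read-out). Compound 1 stands lowest of the three numbers: compound 2 lies above it by a margin beyond the scatter, and compound 3 lies higher still, also beyond the scatter. Compound 4, `O=C(c1ccc(F)c(O)c1)c1ccc2ccccc2n1`, has not yet been measured in this assay. It differs from compound 1 in one place: hydrogen in place of (carboxymethyl)amino on an aromatic carbon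

For the measured compounds named here, no two measured compounds differ in only one place, so no measured step is available for comparison. Still, compound 2 carries no such (carboxymethyl)amino group and gives 64% in this assay, while compound 1 with that group gives 3%. On that basis a rise beyond the scatter is expected for the step of a number 52 percentage points higher from compound 1 to compound 4 (beyond the scatter) in this assay. Compound 4 is estimated to give 55% in this assay, within a range of 25% to 85%.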

Compound 4, a percentage reported as inhibition, at one concentration (the size of the read-out at that concentration, not a potency): 6%
The estimate for compound 4 lay 49 percentage points above the measured number; measured number outside the range, below it.
By their numbers in this assay, from the lowest: compounds 1 and 4 (each within the scatter of the next); then compound 2; then compound 3.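

The number a number 3 percentage points higher from compound 1 to compound 4 (within the scatter) when hydrogen replaces (carboxymethyl)amino on this aromatic carbon, so removing all five heavy atoms of that group makes no change that can be told from the usual scatter in this assay at this position. The group alone therefore cannot account for the low number of compound 1, as compound 4, which lacks it, gives 6% and remains in the same low range. Nothing measured here explains this result.

Still open, going by these compounds, is whether another group on this aromatic carbon, such as a simple amine, a carboxylic acid attached directly to the ring, or a longer chain ending in an ester, would move the number beyond the scatter from that of compound 4. On these data alone, it is also open whether the same swap would read the same way on a core that starts from a higher number.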